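A few compounds are considered here, and "the series" means these few. Any claim that something is new, unique, unknown or untested is made for them only; others in the source may bear on it.

Working notes on a small hydroxyquinoline–indole series assessed in an ADME assay for permeability, using PAMPA, with a stated time of 10 h, tested at 100 ug/mL; on this read-out higher numbers stand for higher permeability and lower numbers for lower permeability. Compound 1 `Oc1cccc2ccc(-c3cc4ccccc4[nH]3)nc12` gives 8 10^-6 cm/s. Compound 2 `Oc1cccc2ccc(-c3cc4cc(Cl)ccc4[nH]3)nc12` carries chloro in place of hydrogen on an aromatic carbon and gives 9.8 10^-6 cm/s; the step is a 1.2-fold higher number from compound 1 to compound 2 (0.09 log units; within the scatter). Compound 3 `Oc1ccc2[nH]c(-c3ccc(O)c4ncccc34)cc2c1` is built on a different core; the difference between the two cores is not broken down here. In this assay compound 3 gives 9.1 10^-6 cm/s, which lies within the scatter of both compound 1 and compound 2, so the three are not distinguished. Compound 4 `Oc1ccc2[nH]c(-c3cc(Cl)c(O)c4ncccc34)cc2c1` has not yet been measured. It differs from compound 3 by chloro in place of hydrogen on an aromatic carbon. This is the same kind of change as that from compound 1 to compound 2, though the place is not identical: in compound 4 the chloro is ortho to a hydroxy group and meta to a large group, as well as meta and para to a fused ring, whereas in compound 2 it is meta and para to a fused ring. Because the step of a 1.2-fold higher number from compound 1 to compound 2 (0.09 log units; within the scatter) was within the scatter, a comparable outcome is expected here, with an estimated step of a 1.2-fold higher number from compound 3 to compound 4 (0.06 log units; within the scatter). Compound 4 is accordingly expected to give about 10.5 10^-6 cm/s, estimated to fall between 6 10^-6 cm/s and 17 10^-6 cm/s.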

Compound 4, apparent permeability: 6.8 10^-6 cm/s
For compound 4 the middle estimate is 1.5-fold (0.19 log units) above the measured one; the measured number falls inside the stated range.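

In this assay, chloro in place of hydrogen on an aromatic carbon gives a 1.3-fold lower number from compound 3 to compound 4 (0.13 log units; within the scatter) on this core. Set beside the same change on the core of compound 1, the two steps are not distinguished: the same change on two cores in this assay, a 1.2-fold higher number (0.09 log units; within the scatter) from compound 1 to compound 2 and a 1.3-fold lower number (0.13 log units; within the scatter) from compound 3 to compound 4, 1.6-fold (0.21 log units) apart, within the scatter of two such steps. This shows no sign that the core alters the result of this change, and on both cores the change leaves the read-out within the scatter; it does not show that the effect is the same on both, as two small steps can only say that neither core gives a large one, and the place also differs, with the chloro in compound 4 ortho to a hydroxy group, which does not hold for compound 2.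

The compounds shown leave open whether a group other than chloro, such as an amine, a carboxylic acid or a longer chain, would give a step beyond the scatter on either core. They also leave open whether chloro at another place on these cores would behave as it does here.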